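The source may hold more compounds than are shown below. What is called first, only, known or untested is meant among the compounds shown, and "the series" means these compounds.

In a functional assay on COR-L23 cells (Homo sapiens) for antiproliferative activity, read by CellTiter-Glo, with a stated time of 4 days (a lower number here means a stronger inhibitor, a higher number a weaker inhibitor), compound 1 `O=C(CCc1cccnc1)Nc1ccc(CN2C(=O)c3ccccc3C2=O)cc1` reads > 10000 nM, which is a limit of the assay and not a number. Compound 2 `O=C(N[C@@H](CO)c1ccc(NC(=O)[C@H]2C[C@@H]2c2cccnc2)cc1)c1ccccc1` gives 630 nM. Compound 3 `C[C@H](NC(=O)[C@@H]1CCCN1C)c1ccc(NC(=O)[C@H]2C[C@@H]2c2cccnc2)cc1` gives 11 nM, the lowest number measured and beyond the scatter from compound 2.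

Compound 4 `C[C@H](NC(=O)c1ncccn1)c1ccc(NC(=O)[C@H]2C[C@@H]2c2cccnc2)cc1` departs from compound 3 in one place: pyrimidin-2-yl in place of 1-methylpyrrolidin-2-yl on a carbonyl carbon. Among the compounds with values here, no measured pair isolates this change. Within the data shown here, compound 2, at 630 nM, shows only that numbers well above that of compound 3 occur when the part around that carbonyl differs. In this assay, a moderate expected rise beyond the scatter is therefore estimated, a 5.5-fold higher number from compound 3 to compound 4 (0.74 log units; beyond the scatter). For compound 4 the estimated value is 60 nM, with an expected range of 12 nM to 300 nM.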

Compound 4, half-maximal inhibitory concentration: 17 nM
Compound 4: the middle estimate sits 3.5-fold (0.55 log units) above what was measured; measured number inside the range.
By their numbers in this assay, from the lowest: compounds 3 and 4 (each within the scatter of the next); then compound 2. At a limit, above all of these: compound 1.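

In this assay, the exchange on this carbonyl carbon gives a 1.5-fold higher number from compound 3 to compound 4 (0.19 log units; within the scatter), so at this position the numbers do not separate a five-membered non-aromatic ring carrying a defined stereocentre from a six-membered aromatic ring. Low numbers here therefore do not depend on 1-methylpyrrolidin-2-yl alone, since pyrimidin-2-yl serves as well. Nothing measured here accounts for why the two groups read alike.

The compounds shown leave open whether a plain phenyl ring or an open-chain amine on this carbonyl carbon would also read alike. They also leave open how far this tolerance extends to larger groups.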